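Shortening the Side Chain on the Saturated Ring Carbon

This account rests on a few compounds, and the source may have more. Where it says the series, first, only, none or still open, it means among the compounds named here.

Compounds measured in a functional assay on NALM-6 cells (Homo sapiens) for inhibition, read by MTT assay, with a stated time of 48 h; on this read-out higher numbers stand for weaker inhibition and lower numbers for stronger inhibition:
- compound 1, `C=C1C(=O)N(c2ccccc2)N(C)C1c1ccccc1`, gives 24400 nM
- compound 2, `C=C1CN(C)N(c2ccccc2)C1=O`, gives 56000 nM
- compound 3, `C=C1C(=O)N(c2ccccc2)N(C)C1CC`, gives 576000 nM

Compound 3 stands at the highest number of the three in this assay: the step of a 10-fold higher number from compound 2 to compound 3 (1.01 log units; beyond the scatter) and the step of a 24-fold higher number from compound 1 to compound 3 (1.37 log units; beyond the scatter) both lie beyond the scatter, so compound 3 is the weakest inhibitor of the measured set. Compound 4, `C=C1C(=O)N(c2ccccc2)N(C)C1C`, differs from compound 3 by hydrogen in place of methyl on a saturated chain carbon bound to a saturated ring carbon. The measured steps that bear on this change are the two that end at compound 3: a 10-fold higher number from compound 2 to compound 3 (1.01 log units; beyond the scatter), where hydrogen became ethyl on the saturated ring carbon, and a 24-fold higher number from compound 1 to compound 3 (1.37 log units; beyond the scatter). Methyl sits between hydrogen and ethyl in size, so compound 4 is expected to fall between compound 2 and compound 3. The step from compound 3 to compound 4 is therefore estimated as a 3.2-fold lower number from compound 3 to compound 4 (0.51 log units; beyond the scatter), towards a lower number. On that basis compound 4 is expected to give 180000 nM in this assay, within a range from 60000 nM to 500000 nM.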

Compound 4, half-maximal inhibitory concentration: 412000 nM
The estimate for compound 4 lay 2.3-fold (0.36 log units) below the measured number; measured number inside the range.
By their numbers in this assay, from the lowest: compound 1; then compound 2; then compounds 4 and 3 (each within the scatter of the next).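

In this assay the change from ethyl to methyl gives a 1.4-fold lower number from compound 3 to compound 4 (0.15 log units; within the scatter) and so does not separate the two groups at this position. What a single methyl does on the saturated ring carbon is therefore new: replacing hydrogen already gives a 7.4-fold higher number from compound 2 to compound 4 (0.87 log units; beyond the scatter) and replacing phenyl gives a 17-fold higher number from compound 1 to compound 4 (1.23 log units; beyond the scatter) so most of the distance seen with ethyl is present with one carbon, while compound 1 with its phenyl goes against any steady rise in the number as the group grows. No measurement at hand offers a reason for this pattern.

The compounds shown leave open whether the low number of compound 1 belongs to phenyl itself or would also hold for another ring, such as cyclohexyl or pyridyl. They also leave open whether a longer chain, such as butyl, would stay level with compound 3 and compound 4.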